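Para halogen swap on an oxime piperazine series

This account rests on a few compounds, and the source may have more. Where it says the series, first, only, none or still open, it means among the compounds named here.

Compound 2 `O/N=C(\CCN1CCN(c2ccccn2)CC1)c1ccc(F)cc1`: 74%
Compound 1 `O/N=C(\CCN1CCN(c2ccccn2)CC1)c1cccc(F)c1`: 72%

In a functional assay on HEK293 cells with D(4) dopamine receptor (Homo sapiens) as the target, read by FLIPR (a lower number here means a smaller maximal response, a higher number a larger maximal response), compound 2 gives 74% and compound 1 gives 72%. Compound 2 holds the higher of the two numbers, but the step of a number 2 percentage points higher from compound 1 to compound 2 (within the scatter) is within the scatter, so the two compounds are not separated by this assay.

Compound 3 `O/N=C(\CCN1CCN(c2ccccn2)CC1)c1ccc(Cl)cc1` has not yet been measured in this assay. It differs from compound 2 by chloro in place of fluoro on an aromatic carbon. Going by the values given here, no measured step changes a halogen for another halogen; the only step known, a number 2 percentage points higher from compound 1 to compound 2 (within the scatter), moved a fluoro between ring positions and stayed within the scatter. On this slender basis a step of about no change at the digits printed from compound 2 to compound 3 (within the scatter) is expected, that is, none beyond the scatter. The maximal response of compound 3 is estimated at 74%, with a range from 60% to 88%.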

Compound 3, largest response reached (reported as efficacy), in percent of the reference or control that the assay uses: 46%
Compound 3: the middle estimate sits 28 percentage points above what was measured, outside the stated range (below it).
By their numbers in this assay, from the lowest: compound 3; then compounds 1 and 2 (each within the scatter of the next).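

At this position, para to a large group, the choice of halogen matters: in this assay, chloro in place of fluoro gives a number 28 percentage points lower from compound 2 to compound 3 (beyond the scatter), whereas the earlier step, which only moved a fluoro around the ring, stayed within the scatter. The change from 3-fluorophenyl to 4-chlorophenyl gives a number 26 percentage points lower from compound 1 to compound 3 (beyond the scatter), so compound 3 stands apart from both fluoro compounds, which themselves remain unseparated. Nothing available explains why the maximal response falls with chloro at this position.

The compounds shown leave open whether bromo, methyl or methoxy on the same aromatic carbon would lower the number further, leave it near that of compound 3 or restore it to the level of compound 2. They also leave open whether chloro would have the same effect on the ring carbon that carries the fluoro in compound 1.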